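Hydroxy for Chloro on the Aryl Arm of Compound 3

A few compounds are considered here, and "the series" means these few. Any claim that something is new, unique, unknown or untested is made for them only; others in the source may bear on it.

Compound 1 `N#Cc1c(-c2ccccc2)nc(SCC(=O)Nn2c(COc3ccc(Cl)cc3Cl)nc3ccccc3c2=O)[nH]c1=O`: 68.4%
Compound 2 `Cn1c(SCC(=O)Nn2c(COc3ccc(Cl)cc3Cl)nc3ccccc3c2=O)nc(-c2ccc(O)cc2)c(C#N)c1=O`: 70.4%
Compound 3 `N#Cc1c(Nc2ccc(O)cc2)nc(SCC(=O)Nn2c(COc3ccc(Cl)cc3Cl)nc3ccccc3c2=O)nc1-c1ccc(Cl)cc1`: 61.4%

Of the compounds shown here, three that share a common core have been tested in a functional assay on the whole organism (strain albino) for inhibition, with Rattus norvegicus as the target, read by paw edema, with stated times of 1 h and 3 h, at a dose of 50 mg/kg by the oral route; a higher number here means a stronger effect of the compound at the dose given, a lower number a weaker effect. Compound 1 gives 68.4%, compound 2 gives 70.4%, and compound 3 gives 61.4%. Compound 3 has the lowest of the three numbers, but its gap to compound 1 and its gap to compound 2 both lie within the usual scatter of such measurements, so the three cannot be ranked against one another.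

Compound 4 `N#Cc1c(Nc2ccc(O)cc2)nc(SCC(=O)Nn2c(COc3ccc(Cl)cc3Cl)nc3ccccc3c2=O)nc1-c1ccc(O)cc1` has not yet been measured. It differs from compound 3 in one place: hydroxy in place of chloro on an aromatic carbon. Going by the values given here, no pair of measured compounds differs in a single place, so no comparable step is available to anchor an expectation. The three measured numbers sit close together. No step beyond the scatter is expected in this assay for this change. Compound 4 is expected to give 64%, with a range from 50% to 78%. This estimate corresponds to an expected step of a number 2.6 percentage points higher from compound 3 to compound 4 (within the scatter), which is expected to stay within the scatter.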

Compound 4, a percentage reported as inhibition, in the whole organism at one dose (the size of the read-out at that dose, not a potency): 56.1%
Estimate against measurement, compound 4: 7.9 percentage points above; measured number inside the range.
By their numbers in this assay, from the lowest: compounds 4, 3, 1 and 2 (each within the scatter of the next, the first and the last beyond it).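

Going by these compounds alone, this pair gives the first comparison that differs in one place only: in this assay, going from 4-chlorophenyl to 4-hydroxyphenyl gives a number 5.3 percentage points lower from compound 3 to compound 4 (within the scatter). At this aromatic carbon, para to a large group, chloro can therefore be exchanged for hydroxy, which adds a hydrogen-bond donor and a hydrogen-bond acceptor, with no step beyond the scatter at this single dose. No available measurement bears on why the step has this size.

On these data alone, it remains open whether another group at this place, such as an amine, a methoxy group or a carboxylic acid, would give a step beyond the scatter. Also open, as far as these compounds go, is whether hydroxy in place of chloro would give a similar step on a different compound.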